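A few compounds are considered here, and "the series" means these few. Any claim that something is new, unique, unknown or untested is made for them only; others in the source may bear on it.

The three measured compounds share one core and differ at a single aromatic carbon. Compound 1 `Fc1ccc(-c2nc3sc(Cc4ccc(Cl)cc4)nn3c2Br)cc1` carries a bromo group there, compound 2 `O=Cc1c(-c2ccc(F)cc2)nc2sc(Cc3ccc(Cl)cc3)nn12` a formyl group, and compound 3 `N#CSc1c(-c2ccc(F)cc2)nc2sc(Cc3ccc(Cl)cc3)nn12` a cyanosulfanyl group. In an ADME assay on CCRF-CEM cells (Homo sapiens) for cytotoxicity, with a stated time of 72 h (a higher number here means a weaker inhibitor, a lower number a stronger inhibitor), compound 1 reaches only the assay limit, > 250000 nM (the limit of > 250000 nM in this assay, at which 1 of the 3 values shown sits). In this assay compound 2 gives 17000 nM, and compound 3 gives 24000 nM. Both replacements of the bromo group move the number strongly: an at least 14-fold lower number from compound 1 to compound 2 (1.16 log units; beyond the scatter) and an at least 10-fold lower number from compound 1 to compound 3 (1.01 log units; beyond the scatter). Between the two numbered compounds the gap is small, a 1.4-fold higher number from compound 2 to compound 3 (0.15 log units; within the scatter), so compound 3 stands beside compound 2 and cannot be set apart from it; the only other value shown is a limit.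

Compound 4 `COc1ccc(-c2nc3sc(Cc4ccc(Cl)cc4)nn3c2SC#N)cc1` differs from compound 3 elsewhere: methoxy in place of fluoro on an aromatic carbon. Within the data shown here, none of the measured steps touches this position; all three concern the carbon bearing the bromo, formyl or cyanosulfanyl group, so no measured step bears on a change from 4-fluorophenyl to 4-methoxyphenyl. With nothing to lean on, a step no larger than the scatter is expected, no change at the digits printed from compound 3 to compound 4 (within the scatter), with no firm direction. Compound 4 is therefore expected to give about 24000 nM in this assay, with a range from 7000 nM to 80000 nM.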

Compound 4, half-maximal inhibitory concentration: 10000 nM
The estimate for compound 4 lay 2.4-fold (0.38 log units) above the measured number; low and high end bracket the measured number.
By their numbers in this assay, from the lowest: compounds 4, 2 and 3 (each within the scatter of the next, the first and the last beyond it). At a limit, above all of these: compound 1.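

Methoxy in place of fluoro, on an aromatic carbon para to a large group, gives a 2.4-fold lower number from compound 3 to compound 4 (0.38 log units; beyond the scatter) in this assay, which shows that the number responds to a change at this position and not only at the carbon bearing the cyanosulfanyl group. This step is modest beside the large replacements of the bromo group, such as an at least 10-fold lower number from compound 1 to compound 3 (1.01 log units; beyond the scatter), so within these compounds the biggest movement remains the one at that other carbon, though that comparison starts from a limit of the assay. Nothing shown gives a measured property of the fluoro or methoxy group that would account for the step from 4-fluorophenyl to 4-methoxyphenyl.

From the compounds shown here alone, this position rests on a single pair, so it remains open whether the same change would move the number in the same direction with a formyl group in place of the cyanosulfanyl group. Going by these compounds, it also remains open how an amine, a carboxylic acid or a longer alkoxy chain such as ethoxy would read at this position in this assay.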